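This account rests on a few compounds, and the source may have more. Where it says the series, first, only, none or still open, it means among the compounds named here.

Measured so far:
compound 1 `N[C@H]1CCc2nc(-c3ccncc3)nc(Nc3cccc(F)c3)c2C1` gives 1600 nM in a functional assay on G-361 cells (Homo sapiens) for antiproliferative activity, read by MTT assay, with a stated time of 72 h; a higher number here means a weaker inhibitor, a lower number a stronger inhibitor
compound 2 `CN(C)c1ccc(Nc2nc(-c3ccncc3)nc3c2CC(N)CC3)cc1` gives 8100 nM in this assay

Compound 2 holds the higher of the two numbers in this assay; compound 1 sits lower, and the gap between them is beyond the scatter. Compound 3 `COc1cccc(Nc2nc(-c3ccncc3)nc3c2CC(N)CC3)c1` is not yet measured. The change from compound 2 to compound 3 is 3-methoxyphenyl in place of 4-(dimethylamino)phenyl on a nitrogen on an aromatic ring. Going by the values given here, no step between measured compounds is at hand, so the expected size rests on compound 1 and compound 2 alone: a modest move toward a lower number, as the step of a 3.2-fold lower number from compound 2 to compound 3 (0.51 log units; beyond the scatter) is expected to show. For compound 3 the estimate in this assay is 2500 nM, with a range from 900 nM to 7000 nM.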

Compound 3, half-maximal inhibitory concentration: 6600 nM
For compound 3 the middle estimate is 2.6-fold (0.42 log units) below the measured one; the range from low to high includes it.
By their numbers in this assay, from the lowest: compound 1; then compounds 3 and 2 (each within the scatter of the next).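

On the nitrogen on an aromatic ring, 3-methoxyphenyl in place of 4-(dimethylamino)phenyl gives a 1.2-fold lower number from compound 2 to compound 3 (0.09 log units; within the scatter) in this assay. Going by these compounds alone, this is the only one-place step, and it does not separate the two groups, so this position tolerates the exchange without a readable change in this read-out. No measurement at hand explains this. 

Still open, from the compounds shown here alone, is whether a carboxylic acid or a morpholine on the phenyl ring would shift the number. Going by these compounds, the contribution of the shared core's amine, for instance against an acetamide there, also remains open.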